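Swapping chloro for trifluoromethyl on the sulfonamide aryl ring

The compounds below may be only part of what the source reports. "The series", "measured", "known", "first", "only" and "open" are said of these compounds alone.

Compound 2 `O=S(=O)(NCCCNc1nccc(-c2[nH]c(-c3ccccc3)nc2-c2ccc(Cl)c(O)c2)n1)c1ccc(Cl)cc1` is the weaker of the two measured compounds: in a functional assay on LOX IMVI cells (Homo sapiens) for cytotoxicity, read by MTT assay, with a stated time of 24 h (a lower number here means a stronger inhibitor, a higher number a weaker inhibitor), compound 2 gives 61300 nM, the higher of the two numbers shown. Going by the values given here, its nearest neighbour, compound 1 `O=S(=O)(NCCCNc1nccc(-c2[nH]c(-c3ccccc3)nc2-c2ccc(F)c(O)c2)n1)c1ccc(Cl)cc1`, gives 14200 nM, and the only measured step, a 4.3-fold higher number from compound 1 to compound 2 (0.64 log units; beyond the scatter), runs between them. Compound 3 `O=S(=O)(NCCCNc1nccc(-c2[nH]c(-c3ccccc3)nc2-c2ccc(Cl)c(O)c2)n1)c1ccc(C(F)(F)F)cc1` carries a different alteration: trifluoromethyl in place of chloro on an aromatic carbon. Among the compounds with values here, no measured pair changes this group on this ring, so the single step from compound 1 to compound 2 does not speak to it directly, and there is no basis for expecting a shift beyond the scatter in either direction. Compound 3 is therefore expected to come out near compound 2, with a wide margin. The estimated step is a 1.0-fold lower number from compound 2 to compound 3 (0.01 log units; within the scatter), expected to stay within the scatter. The estimate for compound 3 is 60000 nM, with a range from 20000 nM to 180000 nM.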

Compound 3, half-maximal inhibitory concentration: 10100 nM
For compound 3 the middle estimate is 5.9-fold (0.77 log units) above the measured one; the whole stated range lies above it.
By their numbers in this assay, from the lowest: compounds 3 and 1 (each within the scatter of the next); then compound 2.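

In this assay, the change from 4-chlorophenyl to 4-(trifluoromethyl)phenyl gives a 6.1-fold lower number from compound 2 to compound 3 (0.78 log units; beyond the scatter), which shows that the number responds to the group on the sulfonamide aryl ring, para to a large group. Going by these compounds alone, the earlier step concerned only the halogen on the hydroxyl-bearing aryl ring, so this is the first sign that a second site on the molecule also moves the value, and here the larger group goes with the lower number. No measurement is available that explains this step.

As far as these compounds go, this reading rests on one pair, so it remains open whether the same change would have a similar effect on the fluoro compound 1. From the compounds shown here alone, how a nitrile, a methoxy group or an amine at this position would compare also remains open.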